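Notes on a pyridinyl-pyrimidine anilide series, toward compound 4

This account rests on a few compounds, and the source may have more. Where it says the series, first, only, none or still open, it means among the compounds named here.

Compound 1 `Cc1ccc(-n2cc(-c3ccc(C)c(C(F)(F)F)c3)nn2)cc1Nc1nccc(-c2cccnc2)n1` — in a functional assay on HL-60 cells (Homo sapiens) for inhibition, read by MTT assay, with a stated time of 72 h (a lower number here means a stronger inhibitor, a higher number a weaker inhibitor), compound 1 sits at the assay limit > 30000 nM, a limit and not a number.
Compound 2 `COc1ccc(-c2cn(-c3ccc(C)c(Nc4nccc(-c5cccnc5)n4)c3)nn2)cc1C(F)(F)F` — in this assay compound 2 gives 21200 nM.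
Compound 3 `Cc1ccc(-n2cc(CCO)nn2)cc1Nc1nccc(-c2cccnc2)n1` — in this assay compound 3 gives 9100 nM.

Compound 3 holds the lowest of the two numbers, compound 2 being nearest (a 2.3-fold lower number from compound 2 to compound 3 (0.37 log units; beyond the scatter)). For compound 1 only a limit is known (the limit of > 30000 nM in this assay, at which 1 of the 3 values shown sits).

Compound 4 `Cc1nnc(-c2ccc(C)c(Nc3nccc(-c4cccnc4)n3)c2)o1` differs from compound 3 by 5-methyl-1,3,4-oxadiazol-2-yl in place of 4-(2-hydroxyethyl)-1H-1,2,3-triazol-1-yl on an aromatic carbon. Within the data shown here, no measured step covers this ring exchange: an at least 3.2-fold lower number from compound 1 to compound 3 (0.51 log units; beyond the scatter) and a 2.3-fold lower number from compound 2 to compound 3 (0.37 log units; beyond the scatter) both keep the triazole and only shrink what sits on it, each lowering the number modestly. Since here the ring itself changes, in this assay no step beyond the scatter is expected in either direction. Compound 4 is therefore estimated at 12000 nM, between 4000 nM and 40000 nM, the expected step being a 1.3-fold higher number from compound 3 to compound 4 (0.12 log units; within the scatter).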

Compound 4, half-maximal inhibitory concentration: > 30000 nM
Compound 4: a limit, no number (the forecaster's own chance of this, stated with the estimate: 25%); at least 2.5-fold (0.39 log units) between middle value and limit.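

At this position, para to a methyl group, the five-membered ring itself matters in this assay: 5-methyl-1,3,4-oxadiazol-2-yl in place of 4-(2-hydroxyethyl)-1H-1,2,3-triazol-1-yl gives an at least 3.2-fold higher number from compound 3 to compound 4 (0.51 log units; beyond the scatter). The earlier steps shown here kept the triazole and lowered the number, whereas this exchange raises it, and it also removes the hydrogen-bond donor. Compound 4 is only a limit and not a number, so the full size of the step is unknown: the limit of > 30000 nM in this assay, at which 2 of the 4 values shown sit.

Whether the ring or the hydroxyl accounts for the lower number of compound 3 stays open. A 2-aminoethyl group or a carboxylic acid on the triazole, or a 2-hydroxyethyl group on the oxadiazole, would bear on that.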